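The source may report more compounds than this note shows. Statements on the series, on what has been measured and on what is new or still open speak of the compounds shown alone.

Compound 1, `COc1ccc2[nH]c(C(=O)N3CC(=O)N(Cc4ccccc4)[C@@H](CN4CCC5(CC4)CC5)C3)cc2c1`, gives 17100 nM in an ADME assay on Vero cells (Chlorocebus sabaeus) for cytotoxicity, with a stated time of 7 days; on this read-out higher numbers stand for lower toxicity in this test and lower numbers for higher toxicity in this test; this is the smaller of the two numbers in hand, though only by a gap within the usual scatter, as compound 2, `O=C(c1cc2cc(C3CC3)ccc2[nH]1)N1CC(=O)N(Cc2ccccc2)[C@@H](CN2CCC(F)CC2)C1`, gives 24500 nM in this assay. Compound 3, `COc1ccc2[nH]c(C(=O)N3CC(=O)N(Cc4ccccc4)[C@@H](CN4CCN(c5ccccn5)CC4)C3)cc2c1`, is not yet measured in this assay. It differs from compound 1 in one place: a group of 12 heavy atoms (9 carbon, 3 nitrogen; one six-membered non-aromatic ring with 2 hetero atoms, one six-membered aromatic ring with 1 hetero atom) in place of a group of 8 heavy atoms (7 carbon, 1 nitrogen; one three-membered non-aromatic ring of carbon only, one six-membered non-aromatic ring with 1 hetero atom), on a saturated chain carbon bound to a saturated ring carbon. For the measured compounds named here, no measured pair shows what such a change does here, so only a small step is expected, a 1.2-fold higher number from compound 1 to compound 3 (0.07 log units; within the scatter), with no clear direction beyond the scatter. Compound 3 is therefore estimated at 20000 nM in this assay, in a range from 8000 nM to 50000 nM.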

Compound 3, half-maximal cytotoxic concentration: > 30000 nM
Compound 3: no number, only a limit; the forecaster's own chance of this, stated with the estimate: 10%; at least 1.5-fold (0.17 log units) between middle value and limit.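

With 4-(pyridin-2-yl)piperazin-1-yl on this saturated chain carbon bound to a saturated ring carbon, this assay shows an at least 1.7-fold higher number from compound 1 to compound 3 (0.24 log units; that floor lies within the scatter). The larger group therefore brings no sign of a lower number at this place, although the floor of the step does not establish a real rise. Compound 3 has only a limit in this read-out: the limit of > 30000 nM in this assay, at which 1 of the 3 values shown sits.

As far as these compounds go, how far compound 3 lies past its limit remains open, as does whether the pyridin-2-yl group contributes to the step. Also open, from the compounds shown here alone, is what a morpholine or a piperazine carrying only a methyl group would give at this place.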